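Hydroxy in Place of Amino on a Fused Two-Ring Core

The compounds below may be only part of what the source reports. "The series", "measured", "known", "first", "only" and "open" are said of these compounds alone.

Measured so far:
compound 1, `Cc1nc2c(OCc3ccc(C(F)(F)F)cc3)cccn2c1N`, giving 0% in a functional assay on the whole organism with Canis familiaris (Canis lupus familiaris) as the target, at a dose of 2 mg/kg by the intravenous route; on this read-out lower numbers stand for a weaker effect and higher numbers for a stronger effect at the one dose given
compound 2, `Cc1nc2c(CCc3ccccc3)cccn2c1N`, giving 71% in this assay

Compound 2 stands highest of the two numbers; its nearest neighbour, compound 1, lies below it by a gap beyond the scatter. Compound 3, `Cc1nc2c(CCc3ccccc3)cccn2c1O`, differs from compound 2 by hydroxy in place of amino on an aromatic carbon. Within the data shown here, no pair of measured compounds shows what this change does. The step in this assay is expected to be downward and of moderate size: a number 26 percentage points lower from compound 2 to compound 3 (beyond the scatter). Compound 3 is therefore estimated to give 45%, with a range from 10% to 80%.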

Compound 3, a percentage reported as inhibition, in the whole organism at one dose (the size of the read-out at that dose, not a potency): 0%
For compound 3 the middle estimate is 45 percentage points above the measured one, and the stated range ends above it.
By their numbers in this assay, from the lowest: compounds 1 and 3 (each within the scatter of the next); then compound 2.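

Exchanging amino for hydroxy on this aromatic carbon, with the rest of the molecule unchanged, gives a number 71 percentage points lower from compound 2 to compound 3 (beyond the scatter) in this assay. The effect at this dose therefore depends on the amino group at this place, even though the two groups match in their counted hydrogen-bond donors and acceptors and in net charge. Nothing available here explains the step. On these data alone, whether a methylamino group, an acetamido group or a methoxy group on this carbon would keep the effect remains open.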